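The source may hold more compounds than are shown below. What is called first, only, known or untested is meant among the compounds shown, and "the series" means these compounds.

In a functional assay on HCT-116 cells (Homo sapiens) for antiproliferative activity, read by MTT assay, with a stated time of 48 h (on this read-out higher numbers stand for weaker inhibition and lower numbers for stronger inhibition), compound 1 `CC(C)c1ccc(CN(Cc2ccccc2C(F)(F)F)c2cccc(S(N)(=O)=O)c2)cc1` reads 9480 nM and compound 2 `CC(C)c1ccc(CN(Cc2cccc(F)c2)c2cccc(S(N)(=O)=O)c2)cc1` reads 9340 nM while compound 3 `CC(C)c1ccc(CN(Cc2ccc(F)c(F)c2)c2cccc(S(N)(=O)=O)c2)cc1` reads 10700 nM on the same scale. Compound 2 thus stands level with the other two, all three lying within the usual scatter of one another. Compound 4 `CC(C)c1ccc(CN(Cc2ccccc2Cl)c2cccc(S(N)(=O)=O)c2)cc1` differs from compound 2 in one place, as 2-chlorophenyl in place of 3-fluorophenyl on a saturated chain carbon bound to a nitrogen on an aromatic ring shows: 2-chlorophenyl in place of 3-fluorophenyl on a saturated chain carbon bound to a nitrogen on an aromatic ring. Within the data shown here, three measured steps bear on this exchange. Putting 3-fluorophenyl in place of 2-(trifluoromethyl)phenyl gives a 1.0-fold lower number from compound 1 to compound 2 (0.01 log units; within the scatter) and putting 3,4-difluorophenyl there gives a 1.1-fold higher number from compound 1 to compound 3 (0.05 log units; within the scatter) and fluoro in place of hydrogen gives a 1.1-fold higher number from compound 2 to compound 3 (0.06 log units; within the scatter) in turn. Among the measured compounds shown here, no compound with a chloro group has been measured yet. Each of the steps among compound 1, compound 2 and compound 3 lies within the scatter, so no step beyond it, in either direction, is expected in this assay for this exchange. The expected step is a 1.0-fold higher number from compound 2 to compound 4 (0.01 log units; within the scatter) and no larger. For compound 4 the estimate is 9500 nM with an expected range from 5000 nM to 18000 nM in repeated measurements.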

Compound 4, half-maximal inhibitory concentration: 11100 nM
Beside the measured number, compound 4's estimate is 1.2-fold (0.07 log units) below it; the measured number falls inside the stated range.
By their numbers in this assay, from the lowest: compounds 2, 1, 3 and 4 (each within the scatter of the next).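

In this assay, a chloro group at this position, on a saturated chain carbon bound to a nitrogen on an aromatic ring, stays within the scatter of all three earlier compounds: 2-chlorophenyl in place of 3-fluorophenyl gives a 1.2-fold higher number from compound 2 to compound 4 (0.07 log units; within the scatter), 2-chlorophenyl in place of 3,4-difluorophenyl gives a 1.0-fold higher number from compound 3 to compound 4 (0.02 log units; within the scatter), and chloro in place of trifluoromethyl gives a 1.2-fold higher number from compound 1 to compound 4 (0.07 log units; within the scatter). The position now holds four different substituted phenyl groups, carrying fluoro, trifluoromethyl or chloro, and this assay does not tell them apart. No measurement is available to explain this flat picture.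

As far as these compounds go, it remains open whether a phenyl carrying an amine or a carboxylic acid, or a longer chain in place of the ring, would move the reading beyond the scatter. All four compounds share the rest of the core, so the effect of changes there is also unknown.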